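This account rests on a few compounds, and the source may have more. Where it says the series, first, only, none or still open, it means among the compounds named here.

Series notes. Compound 1 `O=S(=O)(c1ccc(F)c(Cl)c1)c1cnc2c(F)cccc2c1-c1cccc(Cl)c1`, compound 2 `COc1ccc(-c2c(S(=O)(=O)c3cccc(C#N)c3)cnc3cc(F)ccc23)cc1` and compound 3 `Cc1ccc(S(=O)(=O)c2cnc3cc(F)ccc3c2-c2ccc(F)cc2)cc1C` share one core and have been run in an ADME assay on microsomes from liver (Homo sapiens) for metabolic stability, tested at 2.5 uM; on this read-out higher numbers stand for fast clearance and lower numbers for slow clearance. Compound 1 gives 0.18 mL/min in this assay. Compound 2 gives 0.92 mL/min in this assay, the second highest of the three numbers, above compound 1 and below compound 3, which in this assay gives 9.25 mL/min; both gaps lie beyond the scatter. Compound 4 `COc1ccc(-c2c(S(=O)(=O)c3cccc(F)c3)cnc3cc(F)ccc23)cc1` has not yet been run in this assay. It differs from compound 2 at one place: fluoro in place of cyano on an aromatic carbon. Within the data shown here, no measured pair isolates this change, so in this assay the expected step of a 1.4-fold higher number from compound 2 to compound 4 (0.15 log units; within the scatter) is small, toward faster clearance if anything, and likely not beyond the scatter. Compound 4 is expected to give about 1.3 mL/min in this assay, within 0.4 mL/min to 4 mL/min.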

Compound 4, intrinsic clearance in a liver preparation (reported as CLH), per the amount of preparation that the assay uses: 1.89 mL/min
Compound 4: middle estimate off by 1.5-fold (0.16 log units), on the low side; the range from low to high includes it.
By their numbers in this assay, from the lowest: compound 1; then compound 2; then compound 4; then compound 3.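

In this assay the change from 3-cyanophenyl to 3-fluorophenyl now has a measured pair, with a 2.1-fold higher number from compound 2 to compound 4 (0.31 log units; beyond the scatter), a modest move toward faster clearance. This aromatic carbon is therefore not silent to the swap of nitrile for fluoro, although the step lies only just beyond the scatter. Nothing available accounts for the step. As far as these compounds go, whether an amine or a carboxylic acid on this carbon would shift clearance further, and in which direction, stays open. Also open, from the compounds shown here alone, is whether the same step holds with the other substituents of compound 1 and compound 3.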